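The source may report more compounds than this note shows. Statements on the series, on what has been measured and on what is new or still open speak of the compounds shown alone.

Compound 3 `CC(C)=CCN(C)C1CCN(CCCc2c[nH]c3ccc(-n4cnnc4)cc23)CC1` gives 0.5 nM in an assay on CHO cells for displacement of a labelled ligand from 5-hydroxytryptamine receptor 1D (Homo sapiens) (on this read-out lower numbers stand for stronger inhibition and higher numbers for weaker inhibition), the lowest of the three numbers recorded. Compound 2 `CN(Cc1ccccc1)CC1CCN(CCCc2c[nH]c3ccc(-n4cnnc4)cc23)CC1` gives 0.9 nM in this assay, and the step of a 1.8-fold lower number from compound 2 to compound 3 (0.26 log units; within the scatter) lies within the scatter. Compound 1 `O=S(=O)(NCC1CCN(CCCc2c[nH]c3ccc(-n4cnnc4)cc23)CC1)c1ccccc1` gives 6.2 nM, and the steps of a 6.9-fold lower number from compound 1 to compound 2 (0.84 log units; beyond the scatter) and a 12-fold lower number from compound 1 to compound 3 (1.09 log units; beyond the scatter) both lie beyond the scatter.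

Compound 4 `c1cncc(CNC2CCN(CCCc3c[nH]c4ccc(-n5cnnc5)cc34)CC2)c1` differs from compound 3 in one place: ((pyridin-3-yl)methyl)amino in place of methyl(3-methylbut-2-en-1-yl)amino on a saturated ring carbon. Among the measured compounds shown here, the step that bears most directly on this is the one from compound 2 to compound 3, in which an arylmethyl-bearing amine and the methyl(3-methylbut-2-en-1-yl)amino group gave numbers within the scatter of each other. The larger steps from compound 1 concern the (phenylsulfonyl)amino group, which is not involved here. For the measured compounds named here, no measured compound carries a secondary amine or a pyridine, so the expectation rests on the amine-bearing pair only.

On that basis compound 4 is expected to give a number close to that of compound 3, perhaps slightly higher, with an estimated step of a 3.0-fold higher number from compound 3 to compound 4 (0.48 log units; beyond the scatter). The estimated value for compound 4 in this assay is 1.5 nM, within a range of 0.4 nM to 6 nM.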

Compound 4, half-maximal inhibitory concentration: 35 nM
The estimate for compound 4 lay 23-fold (1.37 log units) below the measured number; the measured number lies above the stated range.
By their numbers in this assay, from the lowest: compounds 3 and 2 (each within the scatter of the next); then compound 1; then compound 4.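

On this assay the saturated ring carbon, three ring bonds from the ring nitrogen, proves sensitive to which amine it carries: ((pyridin-3-yl)methyl)amino in place of methyl(3-methylbut-2-en-1-yl)amino gives a 70-fold higher number from compound 3 to compound 4 (1.85 log units; beyond the scatter) and so a large loss. The earlier amine-bearing compounds had stayed within the scatter of each other, but a 39-fold higher number from compound 2 to compound 4 (1.59 log units; beyond the scatter) shows that an arylmethyl group on an amine does not secure a low number here, and a 5.6-fold higher number from compound 1 to compound 4 (0.75 log units; beyond the scatter) puts this amine behind even the (phenylsulfonyl)amino compound. No evidence available here accounts for the change.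

The change adds a hydrogen-bond donor on the amine and a pyridine ring at once, so the two cannot be told apart. Benzylamino or methyl((pyridin-3-yl)methyl)amino on the same ring carbon would separate them.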